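Series notes: methoxy for methyl at the cytotoxicity limit

The source may hold more compounds than are shown below. What is called first, only, known or untested is meant among the compounds shown, and "the series" means these compounds.

Measured so far:
compound 1 `Fc1ccc(C2CC(c3ccc(Cl)s3)=NN2c2nc(-c3ccccc3)cs2)cc1` — > 500 ug/mL (a limit) in an ADME assay on NIH3T3 cells (Mus musculus) for cytotoxicity, read by XTT assay, with a stated time of 24 h; on this read-out lower numbers stand for stronger inhibition and higher numbers for weaker inhibition
compound 2 `Cc1ccc(-c2csc(N3N=C(c4ccc(Cl)s4)CC3c3ccc(F)cc3)n2)cc1` — > 500 ug/mL (a limit) in this assay

Compound 1 gives only a limit in this assay, > 500 ug/mL. Compound 2 likewise gives only a limit, > 500 ug/mL. The step that the two limits leave unreadable from compound 1 to compound 2 is therefore unreadable; both values sit at the limit of > 500 ug/mL in this assay, at which 2 of the 2 values shown sit.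

Compound 3 `COc1ccc(-c2csc(N3N=C(c4ccc(Cl)s4)CC3c3ccc(F)cc3)n2)cc1` differs from compound 2 by methoxy in place of methyl on an aromatic carbon. No readable measured step bears on this change. For compound 3 a value of 500 ug/mL is expected, with a range from 200 ug/mL to 2000 ug/mL, and most likely the assay again reports only a limit. The expected step of a number no higher from compound 2 to compound 3 (the limit leaves the size open) is none beyond the scatter.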

Compound 3, half-maximal inhibitory concentration: 103 ug/mL
The estimate for compound 3 lay 4.9-fold (0.69 log units) above the measured number, and the stated range ends above it.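

In this assay, methoxy on this aromatic carbon, para to a large group, gives an at least 4.8-fold lower number from compound 2 to compound 3 (0.68 log units; beyond the scatter), so this position can move the read-out off the limit. Methoxy in place of hydrogen at the same place gives an at least 4.8-fold lower number from compound 1 to compound 3 (0.68 log units; beyond the scatter). The step between the hydrogen and methyl compounds cannot be read, because both values are limits: the limit of > 500 ug/mL in this assay, at which 2 of the 3 values shown sit.

From the compounds shown here alone, the true size of both readable steps stays open, since each starts from a limit. Also open, going by these compounds, is whether ethoxy, hydroxyl or an amine at this place would lower the number as methoxy does.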